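The source may hold more compounds than are shown below. What is called first, only, known or untested is meant among the compounds shown, and "the series" means these compounds.

Working notes on the series. In a functional assay (ileum) with Cavia porcellus as the target (a lower number here means a stronger inhibitor, a higher number a weaker inhibitor), compound 1 (`CCCCCCCC/N=C/N1CCC(C(c2ccccc2)c2ccccc2)CC1`) gives 1.8 ug/mL and compound 2 (`CC(=O)CCCCCC/N=C/N1CCC(C(c2ccccc2)c2ccccc2)CC1`) gives 2.2 ug/mL, so compound 1 stands level with compound 2, within the scatter. Compound 3 (`OCCCCCC/N=C/N1CCC(C(c2ccccc2)c2ccccc2)CC1`) has not yet been measured. It carries hydroxy in place of ethyl on a saturated chain carbon, six bonds along the chain from a double-bonded nitrogen. Within the data shown here, only one measured step bears on this change: a 1.2-fold higher number from compound 1 to compound 2 (0.09 log units; within the scatter), with acetyl entering at the same place. Among the measured compounds shown here, that step stays within the scatter, and no measured compound carries hydroxy, so the evidence is thin and sets no firm direction. In this assay, no shift beyond the scatter is therefore expected. The expected step is a 1.4-fold higher number from compound 1 to compound 3 (0.14 log units; within the scatter). For compound 3 the estimated value is 2.5 ug/mL, with an expected range of 1 ug/mL to 6.5 ug/mL.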

Compound 3, half-maximal inhibitory concentration: 0.26 ug/mL
Compound 3: middle estimate off by 9.6-fold (0.98 log units), on the high side; the measured number lies below the stated range.
By their numbers in this assay, from the lowest: compound 3; then compounds 1 and 2 (each within the scatter of the next).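

In this assay, this position proves sensitive to what it carries: hydroxy in place of ethyl gives a 6.9-fold lower number from compound 1 to compound 3 (0.84 log units; beyond the scatter), while acetyl in place of ethyl had stayed within the scatter. Hydroxy in place of acetyl gives an 8.5-fold lower number from compound 2 to compound 3 (0.93 log units; beyond the scatter), so hydroxy stands apart from both ethyl and acetyl here, and the result rests on these three compounds alone. No measurement at hand accounts for this difference.

The change swaps 2 heavy atoms of carbon for 1 oxygen and adds 1 hydrogen-bond donor and 1 hydrogen-bond acceptor, and the compounds shown do not separate these contributions. Going by these compounds, it remains open whether an amine or a carboxylic acid at the same place, or a longer chain carrying hydroxy, would give a similar number.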